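The compounds below may be only part of what the source reports. "The series", "measured", "known", "first", "only" and "open" are said of these compounds alone.

Compound 1 `Cc1c(Cc2cc(F)ccc2S(=O)(=O)c2ccccc2)c2c(n1CC(=O)O)CCNC2=O`, compound 2 `COc1ccc(S(=O)(=O)c2ccccc2)c(Cc2c3c(n(CC(=O)O)c2C)CCNC3=O)c1` and compound 3 `Cc1c(Cc2cc(Br)ccc2S(=O)(=O)c2ccccc2)c2c(n1CC(=O)O)CCNC2=O` share one core and differ only in a single group on one aromatic ring: a fluoro, a methoxy or a bromo. In a functional assay on CHO.K1 cells for antagonist activity at prostaglandin D2 receptor 2 (Homo sapiens), read by GTPgammaS binding, with a stated time of 1 h (a lower number here means a stronger inhibitor, a higher number a weaker inhibitor), compound 1 gives 3.7 nM. In this assay compound 2 gives 3.6 nM. In this assay compound 3 gives 3.9 nM. The three numbers sit together: a 1.0-fold lower number from compound 1 to compound 2 (0.01 log units; within the scatter), a 1.1-fold higher number from compound 2 to compound 3 (0.03 log units; within the scatter) and a 1.1-fold higher number from compound 1 to compound 3 (0.02 log units; within the scatter), so compound 2 cannot be set apart from compound 1 or compound 3 on these figures.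

Compound 4 `COc1ccc(S(=O)(=O)c2ccc(F)cc2)c(Cc2c3c(n(CC(=O)O)c2C)CCNC3=O)c1` is the next step from compound 2. The change is fluoro in place of hydrogen on an aromatic carbon. None of the three measured steps touches this ring; each of them swapped groups on the other aromatic ring, and each stayed within the scatter. They therefore give no direct guide, only the indirect hint that small swaps of a halogen or a methoxy on an aromatic carbon have so far left this series unmoved. On that basis the expectation for compound 4 is a step of a 1.1-fold higher number from compound 2 to compound 4 (0.05 log units; within the scatter), nothing beyond the scatter. The estimate for compound 4 in this assay is 4 nM, expected to fall between 1.5 nM and 10 nM.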

Compound 4, half-maximal inhibitory concentration: 7.1 nM
The estimate for compound 4 lay 1.8-fold (0.25 log units) below the measured number; the measured number falls inside the stated range.
By their numbers in this assay, from the lowest: compounds 2, 1, 3 and 4 (each within the scatter of the next).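

Within the data shown here, this is the first change on the ring of the phenylsulfonyl group, the ring that none of the earlier steps touched. In this assay, going from phenylsulfonyl to (4-fluorophenyl)sulfonyl, with the fluoro para to a large group, gives a 2.0-fold higher number from compound 2 to compound 4 (0.29 log units; within the scatter). The step therefore does not establish a real change in inhibitor strength, although it lies close to the edge of the scatter, so this single pair shows only that a fluoro is accommodated at this position without a clear loss or gain. No supporting measurement is available to explain the size of this step.

The compounds shown leave open how this position responds to groups of a different kind, such as an amine, a carboxylic acid or a longer chain like butyl, any of which would test it far harder than a single fluorine atom does. They also leave open whether a fluoro here would give a similar result when the methoxy on the other aromatic ring is replaced by the fluoro of compound 1 or the bromo of compound 3.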